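Swapping Phenyl for Chloro: Expected Effect on Enzyme Inhibition

The source may hold more compounds than are shown below. What is called first, only, known or untested is meant among the compounds shown, and "the series" means these compounds.

Measured compounds:
Compound 1: `CC(=O)N[C@@H]1[C@@H](O)[C@H](O)[C@@H](CO)O[C@H]1NC(=O)c1cc(Br)c(C)n(Cc2ccc(F)cc2)c1=O`, > 10000 nM
Compound 2: `Cc1c(-c2ccccc2)cc(C(=O)NC2CCCCCC2)c(=O)n1Cc1ccc(F)cc1`, 560 nM

In an assay on U-937 cells for inhibition of Fatty-acid amide hydrolase 1 (Homo sapiens), read by scintillation counting, with a stated time of 15 min (on this read-out lower numbers stand for stronger inhibition and higher numbers for weaker inhibition), compound 2 gives 560 nM, the only plain number among the two results shown. For compound 1 the reported > 10000 nM in this assay is a limit of the assay and not a number, as noted in the limit of > 10000 nM in this assay, at which 1 of the 2 values shown sits. Compound 2 therefore stands alone as the measured point from which the next compound is judged.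

Compound 3, `Cc1c(Cl)cc(C(=O)NC2CCCCCC2)c(=O)n1Cc1ccc(F)cc1`, has not yet been tested in this assay. It differs from compound 2 in one place: chloro in place of phenyl on an aromatic carbon.

Among the compounds with values here, no measured pair differing in a single place is available, so the size of this change cannot be read from the data. The expectation is a moderate weakening, a step in this assay of a 2.7-fold higher number from compound 2 to compound 3 (0.43 log units; beyond the scatter), somewhat beyond the usual scatter. On that basis compound 3 is estimated to give about 1500 nM in this assay, likely between 400 nM and 6000 nM.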

Compound 3, half-maximal inhibitory concentration: 5900 nM
Estimate against measurement, compound 3: 3.9-fold (0.59 log units) below; the range from low to high includes it.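

In this assay, within the data shown here, chloro in place of phenyl on this aromatic carbon gives an 11-fold higher number from compound 2 to compound 3 (1.02 log units; beyond the scatter), the first comparison here between compounds that differ in only one place. It shows that the group at this position, ortho to a methyl group and meta to a cycloheptylcarbamoyl group, has a large effect on the measured number, which compound 2 alone could not reveal. Compound 3 still gives a plain number, 5900 nM, so replacing phenyl with chloro weakens inhibition without taking the result out of the range the assay can read, but nothing measured here accounts for the size of this step.

These two compounds cannot separate what is lost with the phenyl ring from what chloro itself contributes, and one step gives no trend across groups at this position. From the compounds shown here alone, a methoxy group, an amine or a pyridine ring on the same carbon, or a phenyl ring carrying a fluorine, remains open, so it is unknown whether any of them would bring the number back towards that of compound 2.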